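Predicting a Fluorine-Bearing Analogue of Compound 2

The source may hold more compounds than are shown below. What is called first, only, known or untested is meant among the compounds shown, and "the series" means these compounds.

Three compounds on a shared core were examined in a functional assay on A549 cells (Homo sapiens) for antiproliferative activity, read by MTT assay; on this read-out higher numbers stand for weaker inhibition and lower numbers for stronger inhibition. Compound 1 `COc1cc2c(Oc3ccc(NC(=O)Nc4ccccc4Cl)cc3)ccnc2cc1OCCCCCCC(=O)NO` gives 1910 nM, compound 2 `COc1cc2c(Oc3ccc(NC(=O)Nc4ccc(OC(F)(F)F)cc4)cc3)ccnc2cc1OCCCCCCC(=O)NO` gives 3130 nM and compound 3 `COc1cc2c(Oc3ccc(NC(=O)N/N=C/c4ccccc4)cc3)ccnc2cc1OCCCCCCC(=O)NO` gives 3700 nM. Compound 2 stands second highest of the three, nearest to compound 3 and furthest from compound 1, yet every gap lies within the scatter: a 1.6-fold higher number from compound 1 to compound 2 (0.21 log units; within the scatter), a 1.9-fold higher number from compound 1 to compound 3 (0.29 log units; within the scatter) and a 1.2-fold higher number from compound 2 to compound 3 (0.07 log units; within the scatter). Compound 4 `COc1cc2c(Oc3ccc(NC(=O)N/N=C/c4ccccc4F)cc3)ccnc2cc1OCCCCCCC(=O)NO` is not yet measured. Relative to compound 2 the change is a group of 9 heavy atoms (7 carbon, 1 nitrogen, 1 fluorine; one six-membered aromatic ring of carbon only) in place of a group of 11 heavy atoms (7 carbon, 1 oxygen, 3 fluorine; one six-membered aromatic ring of carbon only), on an amide-type nitrogen. Compound 3 carries the same kind of group without the fluorine, so the step of a 1.2-fold higher number from compound 2 to compound 3 (0.07 log units; within the scatter) bears most on it and stayed within the scatter. Compound 4 is therefore expected to show no step beyond the scatter, a 1.1-fold higher number from compound 2 to compound 4 (0.05 log units; within the scatter). Compound 4 is estimated at 3500 nM, within a range from 1800 nM to 7000 nM.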

Compound 4, half-maximal inhibitory concentration: 7780 nM
The estimate for compound 4 lay 2.2-fold (0.35 log units) below the measured number; measured number above the stated range.
By their numbers in this assay, from the lowest: compounds 1, 2 and 3 (each within the scatter of the next); then compound 4.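

In this assay, fluoro in place of hydrogen on an aromatic carbon gives a 2.1-fold higher number from compound 3 to compound 4 (0.32 log units; beyond the scatter), so this group on the amide-type nitrogen responds to a single-atom change, although every step among compounds 1, 2 and 3 stayed within the scatter. Compound 4 also separates from the other two, with a 2.5-fold higher number from compound 2 to compound 4 (0.40 log units; beyond the scatter) and a 4.1-fold higher number from compound 1 to compound 4 (0.61 log units; beyond the scatter). Nothing shown accounts for this shift. The compounds leave open whether the rise is specific to fluoro, or whether chloro, methoxy or an amine on the same aromatic ring would give a similar step.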